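Swapping a thiophene substituent on two related fused cores

The source may report more compounds than this note shows. Statements on the series, on what has been measured and on what is new or still open speak of the compounds shown alone.

Three analogues share a guanidine hydrazone arm and differ in the aromatic group attached to a fused two-ring core. Compound 1 `N=C(N)N/N=C/c1c(-c2cccs2)nc2sccn12` and compound 2 `Cc1cc(-c2nc3sccn3c2/C=N/NC(=N)N)c(C)s1` have the same core, while compound 3 `Cc1cc(-c2nc3n(c2/C=N/NC(=N)N)CCS3)c(C)s1` has a core whose difference from that of compound 2 is not broken down here. In a functional assay on cells (Cancer cell lines, Homo sapiens) for inhibition (on this read-out higher numbers stand for weaker inhibition of growth and lower numbers for stronger inhibition of growth), compound 1 gives 9770 nM, compound 2 gives 15500 nM, and compound 3 gives 13800 nM. The change thiophen-2-yl in place of 2,5-dimethylthiophen-3-yl on an aromatic carbon gave a 1.6-fold lower number from compound 2 to compound 1 (0.20 log units; within the scatter). Compound 4 `N=C(N)N/N=C/c1c(-c2cccs2)nc2n1CCS2` carries the same kind of change on the core of compound 3, (thiophen-2-yl in place of 2,5-dimethylthiophen-3-yl on an aromatic carbon); the place differs in being two ring bonds from two ring atoms that each bear a fused ring. Compound 4 is expected to show a 1.5-fold lower number from compound 3 to compound 4 (0.19 log units; within the scatter), resting on the earlier step of a 1.6-fold lower number from compound 2 to compound 1 (0.20 log units; within the scatter) that lay within the scatter. The estimate for compound 4 in this assay is 9000 nM, between 4500 nM and 18000 nM.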

Compound 4, concentration for 50% growth inhibition: 17400 nM
Estimate against measurement, compound 4: 1.9-fold (0.29 log units) below; the range from low to high includes it.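

In this assay, putting thiophen-2-yl in place of 2,5-dimethylthiophen-3-yl on the core of compound 3 gave a 1.3-fold higher number from compound 3 to compound 4 (0.10 log units; within the scatter). Set beside the earlier step, this result gives no sign that the two cores respond differently: the same change on two cores in this assay, a 1.6-fold lower number (0.20 log units; within the scatter) from compound 2 to compound 1 and a 1.3-fold higher number (0.10 log units; within the scatter) from compound 3 to compound 4, 2.0-fold (0.30 log units) apart, within the scatter of two such steps. Among these compounds, this shows only that the swap left the number within the scatter on both cores; it does not show that the change has a real effect on either core, or that any such effect would be shared.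

As far as these compounds go, all four compounds carry a thiophene at this place, so whether a phenyl ring or a pyridine ring would behave differently remains open. The guanidine hydrazone arm is also shared, leaving open what an amine or a carboxylic acid there would do.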